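The compounds below may be only part of what the source reports. "The series", "measured", "known", "first", "only" and "open" are said of these compounds alone.

The series shares one core joined through a thioether chain to a substituted amine. Compound 1 `C/N=C(/NC#N)NCCSCc1c(C)nc2ccccn12` carries on that amine nitrogen the group with no ring. In a functional assay on the whole organism (stomach) with Rattus norvegicus as the target (a higher number here means that more compound is needed for the effect, a lower number that less compound is needed), compound 1 reaches only the limit of the assay, >> 25 mg/kg. Compound 2 `Cc1nc2ccccn2c1CSCCNc1n[s+]([O-])nc1N` carries instead the five-membered aromatic ring with 3 hetero atoms on the amine nitrogen, and the step from compound 1 to compound 2 is a step that the two limits leave unreadable from compound 1 to compound 2. In this assay compound 2 likewise gives only a limit, >> 25 mg/kg. Compound 3 `Cc1nc2ccccn2c1C(C)SCCNc1n[s+]([O-])nc1N` adds methyl on the saturated chain carbon bound to an aromatic carbon and a sulfur, and the step from compound 2 to compound 3 is a step that the two limits leave unreadable from compound 2 to compound 3. For compound 3 this assay again reports only a limit, >> 25 mg/kg. Compound 3 thus stands where every measured compound stands: the limit of >> 25 mg/kg in this assay, at which 3 of the 3 values shown sit. Compound 4 `Cc1nc2c(OCc3ccccc3)cccn2c1C(C)SCCNc1n[s+]([O-])nc1N` differs from compound 3 by benzyloxy in place of hydrogen on an aromatic carbon. Neither measured step touches this position, and both are unreadable, so no size can be taken from them for the step from compound 3 to compound 4. The expectation for compound 4 is therefore 30 mg/kg, with a range of 5 mg/kg to 150 mg/kg, most probably again a limit. This amounts to an expected step that the limit leaves unreadable from compound 3 to compound 4.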

Compound 4, dose for half-maximal effect: >> 25 mg/kg
Compound 4: only a limit was reported (the forecaster's own chance of this, stated with the estimate: 70%); the middle value is on the limit's open side.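

In this assay, among the compounds shown here, compound 4 gives >> 25 mg/kg as a limit, and since compound 3 is also known only as a limit, no step from compound 3 to compound 4 can be read. The compounds shown leave open what benzyloxy or any other change in the series does to the dose for half-maximal effect, because every value rests on one limit: the limit of >> 25 mg/kg in this assay, at which 4 of the 4 values shown sit.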